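Returning to a carbocyclic ester on the benzylic aryl ring

The source may hold more compounds than are shown below. What is called first, only, known or untested is meant among the compounds shown, and "the series" means these compounds.

Compound 1 `COC(=O)C1=C(c2ccc(CNc3nccc(C)c3NC(=O)CC#N)cc2)CCCC1`: 96%
Compound 2 `COC(=O)c1ccccc1N1CCC(C)(CNc2nccc(C)c2NC(=O)CC#N)CC1`: 90%
Compound 3 `COC(=O)c1cccn1-c1ccc(CNc2nccc(C)c2NC(=O)CC#N)cc1`: 81%

Of the compounds shown here, three sharing one core have been tested in an ADME assay (Homo sapiens) for protein binding. Compound 3 shows the highest unbound fraction of the three. Its nearest neighbour is compound 2, whose value lies within the scatter of compound 3, so no real difference between those two can be claimed. Compound 1 sits clearly apart: a 4.8-fold higher unbound fraction from compound 1 to compound 3 (0.68 log units; beyond the scatter).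

Compound 4 `COC(=O)C1CCCCC1c1ccc(CNc2nccc(C)c2NC(=O)CC#N)cc1` has not yet been measured. It differs from compound 3 in one place: 2-(methoxycarbonyl)cyclohexyl in place of 2-(methoxycarbonyl)-1H-pyrrol-1-yl on an aromatic carbon. The group that enters is closely related to the 2-(methoxycarbonyl)cyclohex-1-en-1-yl group carried by compound 1, so the measured step from compound 1 to compound 3 is the one that bears on this change, and it would run in reverse here. The expected step, a 3.2-fold lower unbound fraction from compound 3 to compound 4 (0.50 log units; beyond the scatter), is therefore a fall in the unbound fraction, likely beyond the scatter. Compound 4 is expected to give about 94% in this assay, estimated between 88% and 97.5%.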

Compound 4, plasma protein binding: 95%
The estimate for compound 4 lay 1.2-fold (0.08 log units) (unbound fraction) above the measured number; low and high end bracket the measured number.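

In this assay the change to 2-(methoxycarbonyl)cyclohexyl gives a 3.8-fold lower unbound fraction from compound 3 to compound 4 (0.58 log units; beyond the scatter) and so sets a second ring of carbon only against the pyrrole of compound 3. The double bond in the ring of compound 1 makes no difference that can be claimed, with a 1.3-fold higher unbound fraction from compound 1 to compound 4 (0.10 log units; within the scatter) and thus a gap that stays within the scatter. Among compounds 1, 3 and 4, the higher unbound fraction therefore goes with the pyrrole ring of compound 3 alone, and none of these three goes against that pattern.

Nothing measured here says why the pyrrole ring differs from the two carbon rings. Going by these compounds, whether a carboxylic acid in place of the methoxycarbonyl group, or a pyridine ring in place of the pyrrole, would raise the unbound fraction further stays open.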